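This account rests on a few compounds, and the source may have more. Where it says the series, first, only, none or still open, it means among the compounds named here.

Of the compounds shown here, two built on a shared core have been measured so far in a toxicity assay on L02 cells (Homo sapiens) for cytotoxicity, read by MTT assay, with a stated time of 72 h; on this read-out lower numbers stand for stronger inhibition and higher numbers for weaker inhibition. In that test compound 1 `O=C1c2c[n+]([O-])c3ccccc3c2C(=O)c2c1c1ccccc1n2CCN1CCCC1` gives 930 nM, the lower of the two numbers, while compound 2 `CC1(C)OC[C@@H](Cn2cc(Cn3c4c(c5ccccc53)C(=O)c3c[n+]([O-])c5ccccc5c3C4=O)nn2)O1` gives 2900 nM, a gap beyond the usual scatter of repeat measurements. Compound 3 `CN1CCN(CCCCCCn2c3c(c4ccccc42)C(=O)c2c[n+]([O-])c4ccccc4c2C3=O)CC1` keeps the core of compound 1 and alters its side chain: 4-(4-methylpiperazin-1-yl)butyl in place of pyrrolidin-1-yl on a saturated chain carbon, two bonds along the chain from an aromatic nitrogen. Here 4-(4-methylpiperazin-1-yl)butyl comes in place of pyrrolidin-1-yl on a saturated chain carbon, two bonds along the chain from an aromatic nitrogen. Among the compounds with values here, no measured pair shows this change alone, so any forecast is loose. Compound 2, at 2900 nM, carries a different side chain and a higher number than compound 1, which makes a modest rise seem likelier than a fall. The expected change in this assay is a 1.7-fold higher number from compound 1 to compound 3 (0.24 log units; within the scatter), a small step toward weaker inhibition that may not clear the scatter. For compound 3 the estimated value is 1600 nM, within a range from 500 nM to 5000 nM.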

Compound 3, half-maximal inhibitory concentration: 3800 nM
Compound 3: the middle estimate sits 2.4-fold (0.38 log units) below what was measured, within the range that was stated.
By their numbers in this assay, from the lowest: compound 1; then compounds 2 and 3 (each within the scatter of the next).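

On a saturated chain carbon, two bonds along the chain from an aromatic nitrogen, replacing pyrrolidin-1-yl with 4-(4-methylpiperazin-1-yl)butyl gives, in this assay, a 4.1-fold higher number from compound 1 to compound 3 (0.61 log units; beyond the scatter). So the number at this position does respond to the side chain, and this change moves it toward weaker inhibition. The change swaps the ring and adds a butyl chain in one step, and no evidence on hand explains the rise.

The compounds shown leave open which part of the change matters. A 4-methylpiperazin-1-yl ring without the butyl chain, or a butyl chain ending in pyrrolidin-1-yl, would each separate the two parts in this assay.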